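Aryl thioether series: swapping dichlorophenyl for fluorophenyl

The source may hold more compounds than are shown below. What is called first, only, known or untested is meant among the compounds shown, and "the series" means these compounds.

Measured so far in a functional assay on OVCAR-3 cells (Homo sapiens) for inhibition, read by sulforhodamine B assay, with a stated time of 48 h; on this read-out higher numbers stand for weaker inhibition of growth and lower numbers for stronger inhibition of growth:
- compound 1 `Nc1cc(N)c2nc(-c3ccccc3)c(Oc3ccc(Cl)c(Cl)c3)nc2c1`: 26900 nM
- compound 2 `Nc1cc(N)c2nc(-c3ccccc3)c(Sc3ccc(Cl)c(Cl)c3)nc2c1`: 46800 nM

Compound 2 sits at the upper end of the two numbers, but only by a 1.7-fold higher number from compound 1 to compound 2 (0.24 log units; within the scatter), so it is not separated from compound 1. Compound 3 `Nc1cc(N)c2nc(-c3ccccc3)c(Sc3ccc(F)cc3)nc2c1` differs from compound 2 by 4-fluorophenyl in place of 3,4-dichlorophenyl on a sulfur. Within the data shown here, no measured step bears on this change; the only step known alters the linking atom, not the aryl group on it. With nothing to indicate a shift, compound 3 is expected to stay near compound 2, a step of a 1.1-fold higher number from compound 2 to compound 3 (0.03 log units; within the scatter) in this assay . The estimate for compound 3 is 50000 nM, range 18000 nM to 130000 nM.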

Compound 3, concentration for total growth inhibition: 33900 nM
Compound 3: the middle estimate sits 1.5-fold (0.17 log units) above what was measured; measured number inside the range.
By their numbers in this assay, from the lowest: compounds 1, 3 and 2 (each within the scatter of the next).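

In this assay, 4-fluorophenyl in place of 3,4-dichlorophenyl on a sulfur gives a 1.4-fold lower number from compound 2 to compound 3 (0.14 log units; within the scatter), so this aryl exchange does not separate the two compounds. (4-Fluorophenyl)sulfanyl in place of 3,4-dichlorophenoxy likewise gives a 1.3-fold higher number from compound 1 to compound 3 (0.10 log units; within the scatter). No supporting evidence bears on this result.

Still open, as far as these compounds go, is whether a group of another kind on the sulfur, such as an aminophenyl, a carboxyphenyl or a longer alkyl chain, would give a step beyond the scatter.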